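The source may hold more compounds than are shown below. What is called first, only, known or untested is meant among the compounds shown, and "the series" means these compounds.

Compound 1 `CC(C)(C)N(Cc1ccccc1Br)Cc1ccccc1Br`: in a functional assay on A549 cells (Homo sapiens) for antiproliferative activity, read by CCK-8 assay, with a stated time of 48 h (a higher number here means a weaker inhibitor, a lower number a stronger inhibitor), compound 1 gives > 30000 nM, a limit of the assay.
Compound 2 `Brc1ccccc1CN(Cc1ccccc1Br)C1CCCCC1`: in this assay compound 2 gives > 30000 nM, also a limit of the assay.

Within the data shown here, compound 2 therefore stands only at a limit in this assay, and the single measured step, a step that the two limits leave unreadable from compound 1 to compound 2, has no readable size, since (the limit of > 30000 nM in this assay, at which 2 of the 2 values shown sit). Compound 3 `Brc1ccccc1CN(Cc1ccccc1Br)c1ccccc1` differs from compound 2 by phenyl in place of cyclohexyl on an amine nitrogen. Among the measured compounds shown here, no measured step bears on this change with a readable size, so no direction can be drawn from the data. Compound 3 is expected to remain near the limit, at about 30000 nM, in the range 10000 nM to 100000 nM. The expected step is thus a number no higher from compound 2 to compound 3 (the limit leaves the size open).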

Compound 3, half-maximal inhibitory concentration: > 30000 nM
Compound 3: only a limit was reported; the forecaster's own chance of this, stated with the estimate: 75%; the middle value lies on the limit itself.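

Compound 3, like compound 1 and compound 2, stands only at a limit, so no step among these compounds can be read: the limit of > 30000 nM in this assay, at which 3 of the 3 values shown sit.

The compounds shown leave open how far any group on the amine nitrogen changes the potency in this assay.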